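Piperidine substituent variation on the aminopyridine amide series

A few compounds are considered here, and "the series" means these few. Any claim that something is new, unique, unknown or untested is made for them only; others in the source may bear on it.

Going by the values given here, compound 2 `Cc1ccc(N2CCC(C)(O)CC2)nc1C(=O)Nc1c(C)ccc(C(=O)O)c1C` gives 87.9 nM in a functional assay on HEK293 cells for antagonist activity at prostaglandin E2 receptor EP4 subtype (Homo sapiens), read by HTRF and cAMP accumulation, with a stated time of 20 min (on this read-out higher numbers stand for weaker inhibition and lower numbers for stronger inhibition), the higher of the two numbers so far. Compound 1 `Cc1ccc(N2CCCC(CO)C2)nc1C(=O)Nc1c(C)ccc(C(=O)O)c1C` gives 14.2 nM, and the change from compound 1 to compound 2 is a 6.2-fold higher number from compound 1 to compound 2 (0.79 log units; beyond the scatter). Compound 3 `Cc1ccc(N2CCC(O)CC2)nc1C(=O)Nc1c(C)ccc(C(=O)O)c1C` is the next member: hydrogen in place of methyl on a saturated ring carbon, so the whole change reads 4-hydroxy-4-methylpiperidin-1-yl to 4-hydroxypiperidin-1-yl. Among the compounds with values here, no measured step isolates this methyl; the single step known swaps the entire piperidine substitution pattern, so it does not bear directly on the removal of one methyl from the hydroxyl-bearing carbon. With no guide, compound 3 is expected near compound 2, a step of a 1.2-fold lower number from compound 2 to compound 3 (0.07 log units; within the scatter) that is not expected to pass beyond the scatter in either direction. The estimate for compound 3 in this assay is therefore 75 nM, with a range from 25 nM to 250 nM.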

Compound 3, half-maximal inhibitory concentration: 19.5 nM
The estimate for compound 3 lay 3.8-fold (0.59 log units) above the measured number, outside the stated range (below it).
By their numbers in this assay, from the lowest: compounds 1 and 3 (each within the scatter of the next); then compound 2.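

In this assay, hydrogen in place of methyl on a saturated ring carbon, the change from 4-hydroxy-4-methylpiperidin-1-yl to 4-hydroxypiperidin-1-yl, gives a 4.5-fold lower number from compound 2 to compound 3 (0.65 log units; beyond the scatter), so this one methyl carries a step beyond the scatter that the earlier swap of the whole substituent could not isolate. The change from 3-(hydroxymethyl)piperidin-1-yl to 4-hydroxypiperidin-1-yl gives a 1.4-fold higher number from compound 1 to compound 3 (0.14 log units; within the scatter), so these two substituents are not told apart on this read-out, and of the three compounds only compound 2, the one with the methyl, stands apart. No measurement at hand offers an explanation for the effect of this methyl.

Still open, on these data alone, is whether an ethyl on the same ring carbon would follow the methyl. As far as these compounds go, it is also open whether an amine or a methoxy group in place of the hydroxyl would keep the numbers of compound 1 and compound 3.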